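A Chain Terminus Stripped to Ethynyl on Compound 3

The source may report more compounds than this note shows. Statements on the series, on what has been measured and on what is new or still open speak of the compounds shown alone.

Of the compounds shown here, three sharing one core have been measured in a functional assay on 1321-N1 cells for agonist activity at P2Y purinoceptor 2 (Homo sapiens), read by scintillation counting and inositol phosphate accumulation; on this read-out lower numbers stand for an effect already at smaller amounts and higher numbers for an effect only at larger amounts of compound. Compound 1 `O=c1[nH]/c(=N\OCCCCc2ccccc2)ccn1[C@@H]1O[C@H](COP(=O)(O)OP(=O)(O)OP(=O)(O)O)[C@@H](O)[C@H]1O` gives 214 nM. Compound 2 `O=c1[nH]/c(=N\OCCCc2cccc([N+](=O)[O-])c2)ccn1[C@@H]1O[C@H](COP(=O)(O)OP(=O)(O)OP(=O)(O)O)[C@@H](O)[C@H]1O` gives 457 nM. Compound 3 `COc1ccc(CCCO/N=c2/ccn([C@@H]3O[C@H](COP(=O)(O)OP(=O)(O)OP(=O)(O)O)[C@@H](O)[C@H]3O)c(=O)[nH]2)cc1` gives 47 nM, the lowest of the three numbers; its nearest neighbour is compound 1, a 4.6-fold lower number from compound 1 to compound 3 (0.66 log units; beyond the scatter) separating them, and compound 2 lies furthest off, a 9.7-fold lower number from compound 2 to compound 3 (0.99 log units; beyond the scatter). Compound 4 `C#CCCCO/N=c1/ccn([C@@H]2O[C@H](COP(=O)(O)OP(=O)(O)OP(=O)(O)O)[C@@H](O)[C@H]2O)c(=O)[nH]1` has not yet been measured. It differs from compound 3 in one place: ethynyl in place of 4-methoxyphenyl on a saturated chain carbon, three bonds along the chain from an oxygen on an unsaturated carbon. The two steps that bear on this change are those leading into compound 3, a 4.6-fold lower number from compound 1 to compound 3 (0.66 log units; beyond the scatter) and a 9.7-fold lower number from compound 2 to compound 3 (0.99 log units; beyond the scatter): exchanging one substituent for another on that chain carbon moved the number by modest amounts, and compound 3 with its 4-methoxyphenyl stands lowest. Removing the 4-methoxyphenyl altogether and leaving only ethynyl has no direct precedent among these compounds, so the number is expected to rise, with the size of the rise uncertain. The expected step is a 5.3-fold higher number from compound 3 to compound 4 (0.73 log units; beyond the scatter) in this assay. Compound 4 is estimated at 250 nM, within a range from 60 nM to 1000 nM.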

Compound 4, half-maximal effective concentration: 168 nM
Compound 4: the middle estimate sits 1.5-fold (0.17 log units) above what was measured; measured number inside the range.
By their numbers in this assay, from the lowest: compound 3; then compounds 4 and 1 (each within the scatter of the next); then compound 2.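

In this assay, a terminus with no ring at all still gives a number in the range of the aryl compounds, so an aromatic ring at this chain carbon is not required for that level of agonist activity: a 1.3-fold lower number from compound 1 to compound 4 (0.11 log units; within the scatter) is no real difference from the benzyl compound, and a 2.7-fold lower number from compound 2 to compound 4 (0.43 log units; beyond the scatter) places ethynyl on the better side of 3-nitrophenyl. Only 4-methoxyphenyl keeps a lead over the small group, with a 3.6-fold higher number from compound 3 to compound 4 (0.55 log units; beyond the scatter), so the loss on stripping the ring is real but modest. Nothing available accounts for these differences.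

The compounds shown leave open whether the triple bond matters, which a saturated pentyl chain in place of pent-4-yn-1-yl would address. Going by these compounds, whether a longer chain ending in ethynyl, or a terminal amine, would hold this level is also open.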